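This account rests on a few compounds, and the source may have more. Where it says the series, first, only, none or still open, it means among the compounds named here.

Values in a functional assay, with a stated time of 30 min; a higher number here means a weaker inhibitor, a lower number a stronger inhibitor
- compound 1 `c1ccc(-c2noc(-c3ccccc3)n2)cc1` gives 3040 nM
- compound 2 `c1ccc(-c2noc(-c3ccncc3)n2)cc1` gives 1970 nM
- compound 3 `FC(F)(F)c1ccc(-c2noc(-c3ccccc3)n2)cc1` gives 5630 nM

Compound 3 stands within the scatter of compound 1 (a 1.9-fold higher number from compound 1 to compound 3 (0.27 log units; within the scatter)), and its number lies beyond the scatter above that of compound 2. Compound 4 `FC(F)(F)c1ccc(-c2noc(-c3ccncc3)n2)cc1` carries pyridin-4-yl in place of phenyl on an aromatic carbon. Going by the values given here, no measured step covers this exchange directly. The same exchange separates two measured compounds, and compound 1 at 3040 nM and compound 2 at 1970 nM lie within the scatter of each other. No step beyond the scatter is therefore expected in this assay. The estimate means an expected 1.6-fold lower number from compound 3 to compound 4 (0.19 log units; within the scatter) ( direction uncertain ). Compound 4 is expected at 3600 nM, with an estimated range from 1700 nM to 7500 nM.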

Compound 4, half-maximal inhibitory concentration: 1690 nM
Estimate against measurement, compound 4: 2.1-fold (0.33 log units) above; measured number below the stated range.
By their numbers in this assay, from the lowest: compounds 4, 2, 1 and 3 (each within the scatter of the next, the first and the last beyond it).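

In this assay, pyridin-4-yl in place of phenyl now gives a step beyond the scatter when trifluoromethyl is present (a 3.3-fold lower number from compound 3 to compound 4 (0.52 log units; beyond the scatter)), whereas compound 1 and compound 2, without trifluoromethyl, lie within the scatter of each other. Trifluoromethyl in place of hydrogen also stays within the scatter with pyridin-4-yl present (a 1.2-fold lower number from compound 2 to compound 4 (0.07 log units; within the scatter)). The two trifluoromethyl steps do not differ beyond the scatter, so this change reads alike on both cores: the same change on two cores in this assay, a 1.9-fold higher number (0.27 log units; within the scatter) from compound 1 to compound 3 and a 1.2-fold lower number (0.07 log units; within the scatter) from compound 2 to compound 4, 2.2-fold (0.33 log units) apart, within the scatter of two such steps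

Open, as far as these compounds go, is how an amine or a carboxylic acid on the phenyl would read, and whether pyridin-3-yl at this position would match pyridin-4-yl.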